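The compounds below may be only part of what the source reports. "The series", "measured", "known", "first", "only" and "open" are said of these compounds alone.

In a functional assay on L1210 cells (Mus musculus) (a higher number here means a weaker inhibitor, a lower number a stronger inhibitor), three compounds built on a shared core have been measured. Compound 1 `CCCCOC[C@H]1OC(n2c(Cl)nc3cc(Cl)c(Cl)cc32)[C@H](O)[C@@H]1O` carries butoxy on a saturated chain carbon bound to a saturated ring carbon, and its reading is a limit, > 100000 nM. Compound 2 `O[C@@H]1[C@@H](CF)OC(n2c(Cl)nc3cc(Cl)c(Cl)cc32)[C@@H]1O` has fluoro in that place, and its reading is also a limit, > 100000 nM. Compound 3 `O[C@@H]1[C@@H](CCl)OC(n2c(Cl)nc3cc(Cl)c(Cl)cc32)[C@@H]1O` has chloro there, and it too stands only at a limit, > 100000 nM. The whole set therefore sits at the limit of > 100000 nM in this assay, at which 3 of the 3 values shown sit.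

Compound 4 `O[C@@H]1[C@@H](CBr)OC(n2c(Cl)nc3cc(Cl)c(Cl)cc32)[C@@H]1O` differs from compound 3 by bromo in place of chloro on a saturated chain carbon bound to a saturated ring carbon, which is bromo in place of chloro, or chloromethyl to bromomethyl. The closest measured change is a step that the two limits leave unreadable from compound 2 to compound 3, since it also exchanges one halogen for another. The other two, a step that the two limits leave unreadable from compound 1 to compound 2 and a step that the two limits leave unreadable from compound 1 to compound 3, can be read no better, so none of the three gives a size or a direction. The expectation for compound 4 therefore rests on compound 3 and its limit of > 100000 nM, and a reading at the same limit is the likeliest outcome. The expected step is a step that the limit leaves unreadable from compound 3 to compound 4, with no change beyond the scatter anticipated. For compound 4 the estimated value is 120000 nM, with an expected range from 40000 nM to 300000 nM.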

Compound 4, half-maximal inhibitory concentration: 100000 nM
Beside the measured number, compound 4's estimate is 1.2-fold (0.08 log units) above it; low and high end bracket the measured number.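

In this assay, going by these compounds alone, compound 4 gives the first plain number of the set, 100000 nM, so bromo on a saturated chain carbon bound to a saturated ring carbon gives a reading rather than a limit. Bromo in place of chloro there gives a number no higher from compound 3 to compound 4 (the limit leaves the size open). Bromo in place of fluoro there gives a number no higher from compound 2 to compound 4 (the limit leaves the size open), and bromo in place of butoxy there gives a number no higher from compound 1 to compound 4 (the limit leaves the size open). None of these three steps can be read for size. The number therefore shows no measurable gain, and it stands level with the ceiling that holds the other compounds: the limit of > 100000 nM in this assay, at which 3 of the 4 values shown sit.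

The compounds shown leave open whether any group in this place can bring the reading clearly under that level, as an iodo group, an amine or a longer chain might or might not. They also leave open how far fluoro, chloro and butoxy really stand from bromo, since each of those three compounds is known only as a limit.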